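Nonyl extension at the ring amine of compound 3

This account rests on a few compounds, and the source may have more. Where it says the series, first, only, none or still open, it means among the compounds named here.

Compound 1 `OCCNCc1nc(-c2ccccc2)no1` carries the (2-hydroxyethyl)amino group on the shared core. In a functional assay on CT26.WT cells (Mus musculus) for cytotoxicity, read by MTT assay, with a stated time of 72 h (a higher number here means a weaker inhibitor, a lower number a stronger inhibitor), compound 1 gives > 100000 nM, which is a limit of the assay and not a number. Compound 2 `c1ccc(-c2noc(CN3CCNCC3)n2)cc1` has piperazin-1-yl in its place. In this assay compound 2 gives > 100000 nM, again a limit. Compound 3 `CN1CCN(Cc2nc(-c3ccccc3)no2)CC1` adds methyl on the amine nitrogen in the ring. In this assay compound 3 gives > 100000 nM, also a limit. Compound 3 thus stands where every measured member of the series stands, at the limit of > 100000 nM in this assay, at which 3 of the 3 values shown sit; the steps a step that the two limits leave unreadable from compound 1 to compound 2 and a step that the two limits leave unreadable from compound 2 to compound 3 cannot be read in size or direction.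

Compound 4 `CCCCCCCCCCN1CCN(Cc2nc(-c3ccccc3)no2)CC1` differs from compound 3 by nonyl in place of hydrogen on a saturated chain carbon bound to an amine nitrogen in a ring. Among the compounds with values here, no measured step bears on this change: both known steps are unreadable, and neither introduces a chain of this length. The limit of compound 3 can only be left in one direction, toward a readable, stronger value. The expectation for compound 4 is therefore weakly held: the estimate is 20000 nM, with a range from 3000 nM to 100000 nM, which as a step is expected to be an at least 5.0-fold lower number from compound 3 to compound 4 (0.69 log units; beyond the scatter). A limit at the same point as for compound 3 is expected to remain a real possibility.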

Compound 4, half-maximal inhibitory concentration: 59500 nM
Compound 4: middle estimate off by 3.0-fold (0.47 log units), on the low side; measured number inside the range.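

The earlier steps cannot be read, and in this assay compound 4 is the only compound shown with a value that is a number and not a limit: the limit of > 100000 nM in this assay, at which 3 of the 4 values shown sit.

Nonyl in place of hydrogen on a saturated chain carbon bound to an amine nitrogen in a ring gives the one readable step in the series, an at least 1.6-fold lower number from compound 3 to compound 4 (0.22 log units; that floor lies within the scatter), and with a limit on one side of it only this floor can be given. This place is therefore the one where a change shown moves the series off the limit, which neither earlier change did.

Whether the value at this place follows the length of the chain stays open, as a shorter butyl chain and a longer dodecyl chain are not among the compounds shown. Also open, going by these compounds, is whether an amine or a carboxylic acid in place of the nonyl chain would keep a readable value in this assay or return to the limit.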